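Replacing the acyclic amine of compound 1 with a cyclic amine

The source may report more compounds than this note shows. Statements on the series, on what has been measured and on what is new or still open speak of the compounds shown alone.

Measured so far in an assay for inhibition of mitogen-activated protein kinase kinase kinase 14 (Homo sapiens), read by luminescence and ADP-Glo, with a stated time of 120 min, in the presence of a further agent that is not named here; on this read-out lower numbers stand for stronger inhibition and higher numbers for weaker inhibition:
compound 1 `CN(C)CCN(C)c1ccc(C#CC(C)(O)c2nccs2)cc1Nc1ncnc2[nH]ccc12` gives 484 nM
compound 2 `CN1CCCN(c2ccc(C#CC(C)(O)c3nccs3)cc2Nc2ncnc3[nH]ccc23)CC1` gives 60.1 nM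
compound 3 `CC(O)(C#Cc1ccc(OC2CCOCC2)c(Nc2ncnc3[nH]ccc23)c1)c1nccs1` gives 112 nM

Compound 1 stands highest of the three numbers; compound 3 is its nearest neighbour and compound 2 the furthest. Compound 4 `CCS(=O)(=O)N1CCN(c2ccc(C#CC(C)(O)c3nccs3)cc2Nc2ncnc3[nH]ccc23)CC1` is not yet measured. It differs from compound 1 thus: 4-(ethylsulfonyl)piperazin-1-yl in place of (2-(dimethylamino)ethyl)(methyl)amino on an aromatic carbon. Two measured steps leave the same group from the same position and bear on this change: an 8.1-fold lower number from compound 1 to compound 2 (0.91 log units; beyond the scatter) and a 4.3-fold lower number from compound 1 to compound 3 (0.64 log units; beyond the scatter). Both replacements lowered the number beyond the scatter, and the two products lie close together, since a 1.9-fold higher number from compound 2 to compound 3 (0.27 log units; within the scatter). A lowering of comparable size is therefore expected for compound 4 in this assay. Compound 4 is estimated at 100 nM, with a range from 30 nM to 330 nM, which is expected to mean a 4.8-fold lower number from compound 1 to compound 4 (0.68 log units; beyond the scatter).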

Compound 4, half-maximal inhibitory concentration: 8.22 nM
Estimate against measurement, compound 4: 12-fold (1.09 log units) above, outside the stated range (below it).
By their numbers in this assay, from the lowest: compound 4; then compounds 2 and 3 (each within the scatter of the next); then compound 1.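

In this assay, 4-(ethylsulfonyl)piperazin-1-yl on this aromatic carbon goes well past the earlier replacements, with a 59-fold lower number from compound 1 to compound 4 (1.77 log units; beyond the scatter). The position also separates the replacing groups, which compounds 2 and 3 alone did not show: a 7.3-fold lower number from compound 2 to compound 4 (0.86 log units; beyond the scatter) and a 14-fold lower number from compound 3 to compound 4 (1.13 log units; beyond the scatter). Nothing at hand bears on the origin of this gain.

On these data alone, whether the gain belongs to the ethylsulfonyl group or to the piperazine ring stays open. 4-Methylpiperazin-1-yl or 4-acetylpiperazin-1-yl at this position would separate the two.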